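This account rests on a few compounds, and the source may have more. Where it says the series, first, only, none or still open, it means among the compounds named here.

Compound 2 `COc1cc(Cl)cc(-c2nn(-c3cccc(NC(=O)Nc4cccc(C(F)(F)F)c4)c3)cc2-c2ccncc2)c1` gives 93% in a functional assay on U-251 cells (Homo sapiens) for inhibition, read by sulforhodamine B assay, with a stated time of 48 h, tested at 0.1 uM (a lower number here means a stronger effect, a higher number a weaker effect of the compound at the concentration tested), which is the highest of the two numbers measured there. Within the data shown here, its nearest neighbour is compound 1 `COc1cc(Cl)cc(-c2nn(-c3cccc(NC(=O)Nc4ccc(Cl)c(C(F)(F)F)c4)c3)cc2-c2ccncc2)c1`, which gives 92% in this assay; the step of a number 1 percentage points higher from compound 1 to compound 2 (within the scatter) is the only measured step, and it lies within the scatter, so the two compounds cannot be told apart. Compound 3 `COc1cc(Cl)cc(-c2nn(-c3cccc(NC(=O)c4cccc(C(F)(F)F)c4)c3)cc2-c2ccncc2)c1` is the next compound to be measured. It differs from compound 2 in one place: 3-(trifluoromethyl)phenyl in place of (3-(trifluoromethyl)phenyl)amino on a carbonyl carbon. Among the measured compounds shown here, the one measured step concerns a hydrogen in place of chloro on an aromatic carbon, a change at another part of the molecule, so nothing measured bears directly on the replacement at the carbonyl carbon. What the two numbers do show is that both compounds leave most of the cell growth untouched at this concentration. Compound 3 is therefore expected to behave similarly, with a step of a number 1 percentage points lower from compound 2 to compound 3 (within the scatter) that is not expected to exceed the scatter. The estimate for compound 3 in this assay is 92%, with a range from 78% to 102%.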

Compound 3, a percentage reported as activity, at one concentration (the size of the read-out at that concentration, not a potency): 91%
The estimate for compound 3 lay 1 percentage points above the measured number, within the range that was stated.
By their numbers in this assay, from the lowest: compounds 3, 1 and 2 (each within the scatter of the next).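

Among these compounds, the earlier compounds showed only that the chloro group on the outer aromatic ring could be exchanged for hydrogen without a readable difference; compound 3 extends this to the carbonyl carbon, where 3-(trifluoromethyl)phenyl takes the place of (3-(trifluoromethyl)phenyl)amino. In this assay, this exchange gives a number 2 percentage points lower from compound 2 to compound 3 (within the scatter), and the exchange that also lacks the chloro group gives a number 1 percentage points lower from compound 1 to compound 3 (within the scatter), so neither step separates the compounds, even though the group that enters has no hydrogen-bond donor and the group that leaves has one. At this single concentration, then, the amino link on the carbonyl carbon shows no readable contribution, though the high numbers of all three compounds give little room to see one, and no measurement available here explains the result.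

The compounds shown leave open whether a carboxylic acid, a morpholine or a longer chain on the carbonyl carbon would give a number beyond the scatter. They also leave open whether compound 3 and its neighbours would differ at higher concentrations, where a stronger effect could reveal differences that this single test cannot show.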